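The source may report more compounds than this note shows. Statements on the series, on what has been measured and on what is new or still open speak of the compounds shown alone.

Measured so far in a functional assay on HepG2 cells (Homo sapiens) for inhibition, read by MTT assay, with a stated time of 72 h; a higher number here means a weaker inhibitor, a lower number a stronger inhibitor:

Compound 1 `Cc1ccccc1-n1cc(COc2cccc(NC(=O)Nc3ccc(Cl)c(C(F)(F)F)c3)c2)nn1` gives 3440 nM.
Compound 2 `CCc1ccc(-n2cc(COc3cccc(NC(=O)Nc4ccc(Cl)c(C(F)(F)F)c4)c3)nn2)cc1` gives 1950 nM.
Compound 3 `O=C(Nc1cccc(OCc2cn(-c3ccc(F)cc3)nn2)c1)Nc1ccc(Cl)c(C(F)(F)F)c1` gives 1350 nM.

Compound 3 holds the lowest of the three numbers, but its gap to compound 2 lies within the scatter, so no order between those two can be read; only against compound 1 does it stand apart, a 2.5-fold lower number from compound 1 to compound 3 (0.41 log units; beyond the scatter), a modest step. The remaining steps are small: a 1.8-fold lower number from compound 1 to compound 2 (0.25 log units; within the scatter) and a 1.4-fold lower number from compound 2 to compound 3 (0.16 log units; within the scatter).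

Compound 4 `O=C(Nc1cccc(OCc2cn(-c3ccc(I)cc3)nn2)c1)Nc1ccc(Cl)c(C(F)(F)F)c1` is the next point. iodo in place of fluoro on an aromatic carbon Of the measured steps, only the change from compound 2 to compound 3 bears on this substituent, where fluoro in place of ethyl gave a 1.4-fold lower number from compound 2 to compound 3 (0.16 log units; within the scatter), within the scatter. Iodo itself has no precedent in the series, and the whole spread across three varied groups on this ring is narrow. The expected change in this assay for compound 4 is therefore small, a 1.1-fold lower number from compound 3 to compound 4 (0.05 log units; within the scatter), nothing beyond the scatter. Compound 4 is estimated at 1200 nM with a range from 500 nM to 3000 nM.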

Compound 4, half-maximal inhibitory concentration: 2690 nM
Beside the measured number, compound 4's estimate is 2.2-fold (0.35 log units) below it; measured number inside the range.
By their numbers in this assay, from the lowest: compounds 3, 2, 4 and 1 (each within the scatter of the next, the first and the last beyond it).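

In this assay, iodo in place of fluoro gives a 2.0-fold higher number from compound 3 to compound 4 (0.30 log units; within the scatter), so the 4-iodophenyl and 4-fluorophenyl groups cannot be told apart here. Among these compounds, the comparisons with the other two groups read the same way, with a 1.4-fold higher number from compound 2 to compound 4 (0.14 log units; within the scatter) and a 1.3-fold lower number from compound 1 to compound 4 (0.11 log units; within the scatter), so a fourth aryl group leaves compound 1 and compound 3 as the only pair lying beyond the scatter. No measurement at hand accounts for the values of these groups.

Open, as far as these compounds go, is what a 4-aminophenyl or 4-carboxyphenyl group would give in place of 4-fluorophenyl, as all four compounds carry only ethyl, methyl or halogen on this ring. Also open, from the compounds shown here alone, is whether this narrow spread would hold if the chloro and trifluoromethyl groups of the shared core were replaced.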